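The compounds below may be only part of what the source reports. "The series", "measured", "known", "first", "only" and "open" are said of these compounds alone.

Working notes on the series in a functional assay on A549 cells (Homo sapiens) for antiproliferative activity, read by MTT assay, with a stated time of 72 h; on this read-out higher numbers stand for weaker inhibition and lower numbers for stronger inhibition.

Of the compounds shown here, three of the shared core have numbers so far. Compound 1 `O=C(Nc1ccc(Oc2ccnc3[nH]ccc23)cc1)c1cc2cccnc2n(-c2ccc(Cl)cc2)c1=O` gives 290 nM in this assay. Compound 2 `O=C(Nc1ccc(Oc2ccnc3[nH]ccc23)cc1)c1cc2cccnc2n(-c2ccc(Br)cc2F)c1=O` gives 1570 nM in this assay. Compound 3 `O=C(Nc1ccc(Oc2ccnc3[nH]ccc23)c(F)c1)c1cc2cccnc2n(-c2ccc(Cl)cc2)c1=O` gives 110 nM in this assay, the lowest number of the three, with compound 1 nearest to it and compound 2 furthest from it.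

Two single-point steps are known. Putting fluoro in place of hydrogen on an aromatic carbon gave a 2.6-fold lower number from compound 1 to compound 3 (0.42 log units; beyond the scatter). Swapping the ring on the aromatic nitrogen gave a 5.4-fold higher number from compound 1 to compound 2 (0.73 log units; beyond the scatter).

Compound 4 `O=C(Nc1ccc(Oc2ccnc3[nH]ccc23)c(F)c1)c1cc2cccnc2n(-c2ccc(Br)cc2F)c1=O` is the next one to be run in this assay. It differs from compound 3 by 4-bromo-2-fluorophenyl in place of 4-chlorophenyl on an aromatic nitrogen. Within the data shown here, the only measured step that bears on this change is the one from compound 1 to compound 2, namely a 5.4-fold higher number from compound 1 to compound 2 (0.73 log units; beyond the scatter), which is the same swap made on the compound lacking the fluoro on the aromatic carbon. Among the measured compounds shown here, with a single precedent and no second example, the expectation is a step of about that size in the same direction, so a higher number. Compound 4 is therefore expected to give 600 nM in this assay, in a range of 250 nM to 1500 nM. The expected step is a 5.5-fold higher number from compound 3 to compound 4 (0.74 log units; beyond the scatter).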

Compound 4, half-maximal inhibitory concentration: 460 nM
Beside the measured number, compound 4's estimate is 1.3-fold (0.12 log units) above it, and the stated range covers the measured number.
By their numbers in this assay, from the lowest: compound 3; then compounds 1 and 4 (each within the scatter of the next); then compound 2.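

On the aromatic nitrogen, 4-bromo-2-fluorophenyl in place of 4-chlorophenyl raises the number a second time in this assay, giving a 4.2-fold higher number from compound 3 to compound 4 (0.62 log units; beyond the scatter), so the step is no longer known from a single core: the same change on two cores in this assay, a 5.4-fold higher number (0.73 log units; beyond the scatter) from compound 1 to compound 2 and a 4.2-fold higher number (0.62 log units; beyond the scatter) from compound 3 to compound 4, 1.3-fold (0.11 log units) apart, within the scatter of two such steps

Fluoro in place of hydrogen on an aromatic carbon likewise lowers the number with the other group on the aromatic nitrogen, giving a 3.4-fold lower number from compound 2 to compound 4 (0.53 log units; beyond the scatter), so this step also holds on a second core: the same change on two cores in this assay, a 2.6-fold lower number (0.42 log units; beyond the scatter) from compound 1 to compound 3 and a 3.4-fold lower number (0.53 log units; beyond the scatter) from compound 2 to compound 4, 1.3-fold (0.11 log units) apart, within the scatter of two such steps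

Across these four compounds, each change therefore has a similar size whichever form the other place takes, and the numbers of compound 1 and compound 4 lie within the scatter of each other.

The swap on the aromatic nitrogen alters two things at once, the halogen at the 4-position and the added fluoro, so the four compounds do not show which of them carries the step; 4-bromophenyl and 4-chloro-2-fluorophenyl would separate the two. Also open, on these data alone, is how the series reads with a methoxy group or an amine in place of the halogen on that ring.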